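This account rests on a few compounds, and the source may have more. Where it says the series, first, only, none or still open, it means among the compounds named here.

Measured so far in a functional assay on A-431 cells (Homo sapiens) for antiproliferative activity, read by MTT assay, with a stated time of 72 h; on this read-out lower numbers stand for stronger inhibition and higher numbers for weaker inhibition:
- compound 1 `COc1cc2ncnc(Nc3ccc(Cl)cc3)c2cc1OCCCCC(=O)Nc1ccc(S(N)(=O)=O)cc1`: 7120 nM
- compound 2 `COc1cc2ncnc(Nc3cc(F)c(F)c(F)c3)c2cc1OCCCCC(=O)Nc1ccc(S(N)(=O)=O)cc1`: 23400 nM
- compound 3 `NS(=O)(=O)c1ccc(NC(=S)Nc2ccc3ncnc(Nc4ccc(F)c(Cl)c4)c3c2)cc1`: 37600 nM

Compound 3 gives the highest number of the three; compound 2 lies within the scatter of it, compound 1 beyond it. Compound 4 `NS(=O)(=O)c1ccc(NC(=S)Nc2ccc3ncnc(Nc4ccc(C(F)(F)F)cc4)c3c2)cc1` differs from compound 3 by 4-(trifluoromethyl)phenyl in place of 3-chloro-4-fluorophenyl on a nitrogen on an aromatic ring. For the measured compounds named here, the only measured step at the same nitrogen is a 3.3-fold higher number from compound 1 to compound 2 (0.52 log units; beyond the scatter), a modest rise on a pair that differs from compound 3 elsewhere in the molecule, so it bears on the change only loosely. Going by the values given here, no step for the present swap exists. The expected step of a 1.1-fold higher number from compound 3 to compound 4 (0.03 log units; within the scatter) is therefore small, with no clear direction beyond the scatter. Compound 4 is estimated at 40000 nM, range 14000 nM to 110000 nM, in this assay.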

Compound 4, half-maximal inhibitory concentration: 18000 nM
The estimate for compound 4 lay 2.2-fold (0.35 log units) above the measured number; the measured number falls inside the stated range.
By their numbers in this assay, from the lowest: compound 1; then compounds 4, 2 and 3 (each within the scatter of the next, the first and the last beyond it).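

In this assay, replacing 3-chloro-4-fluorophenyl with 4-(trifluoromethyl)phenyl on the nitrogen gives a step beyond the scatter: a 2.1-fold lower number from compound 3 to compound 4 (0.32 log units; beyond the scatter). This step is lower where a 3.3-fold higher number from compound 1 to compound 2 (0.52 log units; beyond the scatter) is higher, but the two involve different groups on different cores, so they set no single trend at this nitrogen. Nothing available explains the step.

From the compounds shown here alone, whether 4-(trifluoromethyl)phenyl would read the same way on the core of compound 1 remains open. So does the effect of a carboxylic acid or an amine in place of the trifluoromethyl.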